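Carbamate ester swapped for a thioester in a GIP receptor series

The compounds below may be only part of what the source reports. "The series", "measured", "known", "first", "only" and "open" are said of these compounds alone.

Measured compounds:
Compound 1, `Cc1nc(S(C)(=O)=O)ccc1Oc1ncnc(OC2CCN(C(=O)OC(C)(C)C#N)CC2)c1F`, gives 97% in a functional assay on isolated protein for inhibition of Glucose-dependent insulinotropic receptor (Rattus norvegicus), read by HTRF and cAMP accumulation; on this read-out higher numbers stand for larger maximal responses and lower numbers for smaller maximal responses.
Compound 2, `Cc1nc(S(C)(=O)=O)ccc1Oc1ncnc(OC2CCN(C(=O)O[C@H](C)CF)CC2)c1F`, gives 79% in this assay.
Compound 3, `Cc1nc(S(C)(=O)=O)ccc1Oc1ncnc(OC2CCN(C(=O)O[C@H](C)C(F)(F)F)CC2)c1F`, gives 85% in this assay.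

Compound 2 has the lowest of the three numbers. Its nearest neighbour is compound 3, a number 6 percentage points higher from compound 2 to compound 3 (within the scatter); its furthest is compound 1, since a number 18 percentage points lower from compound 1 to compound 2 (beyond the scatter). Compound 3 also sits under compound 1, as a number 12 percentage points lower from compound 1 to compound 3 (beyond the scatter).

The unmeasured compound 4, `Cc1nc(S(C)(=O)=O)ccc1Oc1ncnc(OC2CCN(C(=O)SC(C)C)CC2)c1F`, differs from compound 2 only at the carbonyl carbon whose other neighbours are an amide-type nitrogen in a ring: a group of 4 heavy atoms (3 carbon, 1 sulfur; no ring) in place of a group of 5 heavy atoms (3 carbon, 1 oxygen, 1 fluorine; no ring), on a carbonyl carbon.

Going by the values given here, none of the measured steps exchanges the oxygen of this ester for sulfur, so no step bears directly on the change. The closest comparisons are the three exchanges of the group on that oxygen, which moved the maximal response modestly at most and kept all three values close to full response. Compound 4 is therefore expected to stay in that same band, and its maximal response is estimated at 85% (range 68% to 100%). The expected step is a number 6 percentage points higher from compound 2 to compound 4 (within the scatter), which is not beyond the scatter.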

Compound 4, largest response reached (reported as efficacy), in percent of the reference or control that the assay uses: 81%
Beside the measured number, compound 4's estimate is 4 percentage points above it; the range from low to high includes it.
By their numbers in this assay, from the lowest: compounds 2, 4 and 3 (each within the scatter of the next); then compound 1.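

In this assay, the result shows that this carbonyl carbon tolerates a sulfur link as well as an oxygen link: with isopropylsulfanyl in place of the earlier groups, there is a number 2 percentage points higher from compound 2 to compound 4 (within the scatter) and also a number 4 percentage points lower from compound 3 to compound 4 (within the scatter), so compound 4 cannot be told apart from either fluorinated carbamate. The third comparison gives a number 16 percentage points lower from compound 1 to compound 4 (beyond the scatter) and shows that compound 1, with its 1-cyano-1-methylethoxy group, stands apart from compound 4 as it does from compound 2 and compound 3. No supporting data are available to explain these numbers.

From the compounds shown here alone, whether the sulfur itself makes any difference stays open, as the change to compound 4 also replaces the rest of the group, and an isopropoxy group on the same carbonyl carbon would give the direct oxygen partner of isopropylsulfanyl. Also open, going by these compounds, is how an isopropylamino group would read at this place, and whether a 1-cyano-1-methylethylsulfanyl group would keep the higher maximal response of compound 1 on a sulfur link.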